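The compounds below may be only part of what the source reports. "The series", "measured", "known", "first", "only" and "open" are said of these compounds alone.

In an ADME assay on microsomes from liver (Rattus norvegicus) for metabolic stability, with a stated time of 10 min (on this read-out lower numbers stand for a less stable compound and higher numbers for a more stable compound), three compounds built on one shared core have been measured. Compound 1 `COc1nc(C)c(Nc2nc(Cl)cn([C@H](C)C3CC3)c2=O)cc1C` gives 77%, compound 2 `CCOc1nc(C)c(Nc2nc(Cl)cn([C@H](C)C3CC3)c2=O)cc1C` gives 93%, and compound 3 `Cc1cc(Nc2nc(Cl)cn([C@H](C)C3CC3)c2=O)c(C)nc1N1CCCC1` gives 57%, the lowest of the three numbers. The next compound, compound 4 `Cc1cc(Nc2nc(Cl)cn([C@H](C)C3CC3)c2=O)c(C)nc1OC(F)F`, differs from compound 3 at a single place: difluoromethoxy in place of pyrrolidin-1-yl on an aromatic carbon. In words, difluoromethoxy stands in place of pyrrolidin-1-yl on an aromatic carbon.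

Going by the values given here, two measured steps concern that same place. The first, with pyrrolidin-1-yl replacing methoxy, is modest: a number 20 percentage points lower from compound 1 to compound 3 (beyond the scatter). The second, with pyrrolidin-1-yl replacing ethoxy, is large: a number 36 percentage points lower from compound 2 to compound 3 (beyond the scatter). Both point the same way, and compound 4 would reverse that swap with another group joined through oxygen. Among the compounds with values here, the guide is imperfect, as no measured compound carries difluoromethoxy, and the choice of group joined through oxygen itself matters: a number 16 percentage points higher from compound 1 to compound 2 (beyond the scatter).

An upward step of modest to large size is therefore expected, resting on the two steps to compound 3 shown above. For compound 4 the expected change is a number 27 percentage points higher from compound 3 to compound 4 (beyond the scatter). For compound 4 the estimated value is 84%, with an expected range from 68% to 97%.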

Compound 4, percent of the compound remaining: 100%
Beside the measured number, compound 4's estimate is 16 percentage points below it; measured number above the stated range.
By their numbers in this assay, from the lowest: compound 3; then compound 1; then compounds 2 and 4 (each within the scatter of the next).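

In this assay, the step of a number 43 percentage points higher from compound 3 to compound 4 (beyond the scatter) shows that a third group joined through oxygen also stands clear of pyrrolidin-1-yl at this aromatic carbon, so methoxy, ethoxy and difluoromethoxy all give numbers beyond the scatter above that of compound 3, with no compound shown going against this. The two fluorine atoms separate the new group from methoxy, with a number 23 percentage points higher from compound 1 to compound 4 (beyond the scatter), but not from ethoxy, with a number 7 percentage points higher from compound 2 to compound 4 (within the scatter), so on this read-out difluoromethoxy and ethoxy cannot be told apart, and only methoxy stands apart among the groups joined through oxygen. Nothing at hand explains why these groups differ in this way.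

The compounds shown leave open how trifluoromethoxy, an open-chain amine such as dimethylamino or a larger ring such as piperidin-1-yl would read at this aromatic carbon, and so whether the low number of compound 3 goes with amines in general or with pyrrolidin-1-yl alone. They also leave open whether difluoromethoxy would keep its standing if a group such as a nitrile took the place of the chlorine on the shared core.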